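Hydroxyphenyl position and cytotoxicity in the amide series

This account rests on a few compounds, and the source may have more. Where it says the series, first, only, none or still open, it means among the compounds named here.

Measured compounds:
compound 1, `Cc1cc(C)cc(S(=O)(=O)c2c(C(=O)NC(C)c3ccccc3O)[nH]c3ccc(Cl)cc23)c1`, 21800 nM
compound 2, `Cc1cc(C)cc(S(=O)(=O)c2c(C(=O)NC(C)c3cccc(O)c3)[nH]c3ccc(Cl)cc23)c1`, 16000 nM
compound 3, `Cc1cc(C)cc(S(=O)(=O)c2c(C(=O)NCC(=O)NCc3ccccc3O)[nH]c3ccc(Cl)cc23)c1`, limit only

All values come from an ADME assay on MT4 cells (Homo sapiens) for cytotoxicity, read by MTT assay; on this read-out lower numbers stand for higher toxicity in this test and higher numbers for lower toxicity in this test. For compound 3 the result is a limit of the assay, > 47300 nM.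

Compound 2 differs from compound 1 by 3-hydroxyphenyl in place of 2-hydroxyphenyl on a saturated chain carbon bound to an amide-type nitrogen and a saturated chain carbon. This gave a 1.4-fold lower number from compound 1 to compound 2 (0.13 log units; within the scatter). Compound 3 differs from compound 1 by a group of 12 heavy atoms (9 carbon, 1 nitrogen, 2 oxygen; one six-membered aromatic ring of carbon only) in place of a group of 9 heavy atoms (8 carbon, 1 oxygen; one six-membered aromatic ring of carbon only), on an amide-type nitrogen. The steps of an at least 2.1-fold higher number from compound 1 to compound 3 (0.33 log units; beyond the scatter) and an at least 2.9-fold higher number from compound 2 to compound 3 (0.47 log units; beyond the scatter) are known only as floors owing to the limit of > 47300 nM in this assay, at which 1 of the 3 values shown sits.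

Compound 4, `Cc1cc(C)cc(S(=O)(=O)c2c(C(=O)NCC(=O)NCc3cccc(O)c3)[nH]c3ccc(Cl)cc23)c1`, has not been measured in this assay. It differs from compound 3 by 3-hydroxyphenyl in place of 2-hydroxyphenyl on a saturated chain carbon bound to an amide-type nitrogen. This is the same kind of change as from compound 1 to compound 2, not the same change: there the place was a saturated chain carbon bound to an amide-type nitrogen and a saturated chain carbon, here it is a saturated chain carbon bound to an amide-type nitrogen. The two cores themselves are set apart as described above for compound 1 and compound 3.

For compound 4 the step is expected to be a step that the limit leaves unreadable from compound 3 to compound 4, since the corresponding measured step was a 1.4-fold lower number from compound 1 to compound 2 (0.13 log units; within the scatter) and stayed within the scatter. Compound 4 is therefore estimated at about 50000 nM, with an expected range from 22000 nM to 150000 nM, and a further limit of the assay rather than a number is the likelier outcome in this assay.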

Compound 4, half-maximal cytotoxic concentration: > 47500 nM
Compound 4 was reported as a limit (the forecaster's own chance of this, stated with the estimate: 70%); the middle value is on the limit's open side.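

In this assay compound 4 is reported as a limit of the assay, > 47500 nM. Compound 3 is also reported as a limit, so the step for 3-hydroxyphenyl in place of 2-hydroxyphenyl on the core of compound 3 cannot be read, and the result neither confirms nor rules out that this change carries over from the core of compound 1, where it gave a 1.4-fold lower number from compound 1 to compound 2 (0.13 log units; within the scatter). What can be read concerns the change of core rather than the hydroxyl position, with an at least 2.9-fold higher number from compound 2 to compound 4 (0.47 log units; beyond the scatter) and an at least 2.1-fold higher number from compound 1 to compound 4 (0.33 log units; beyond the scatter), and both steps are only floors, set by: the limit of > 47500 nM in this assay, at which 1 of the 4 values shown sits.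

The compounds shown leave open where the actual values of compound 3 and compound 4 lie, and so whether 2-hydroxybenzyl and 3-hydroxybenzyl differ at all on this core. They also leave open how an amine or a carboxylic acid in place of the hydroxyl, or a longer chain in place of the 3-hydroxybenzyl, would read in this assay.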